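A few compounds are considered here, and "the series" means these few. Any claim that something is new, unique, unknown or untested is made for them only; others in the source may bear on it.

Compound 3 `CCCCCCC(C)(O)CC(=O)O[C@H](CC=C(C)C)C1=CC(=O)c2c(O)ccc(O)c2C1=O` reports only a limit in a functional assay on HeLa cells (Homo sapiens) for cytotoxicity, read by MTT assay (a lower number here means a stronger inhibitor, a higher number a weaker inhibitor), > 100000 nM, and not a number. The change to compound 4 `CC(C)=CC[C@@H](OC(=O)CC(O)c1ccccc1)C1=CC(=O)c2c(O)ccc(O)c2C1=O` is hydroxy(phenyl)methyl in place of 1-hydroxy-1-methylheptyl on a saturated chain carbon bound to a carbonyl carbon. Two measured relatives bear on it: compound 1 `CC(C)=CC[C@@H](OC(=O)CCO)C1=CC(=O)c2c(O)ccc(O)c2C1=O` gives 67600 nM and compound 2 `CCCC(O)CC(=O)O[C@H](CC=C(C)C)C1=CC(=O)c2c(O)ccc(O)c2C1=O` gives 59300 nM. Between them lies a 1.1-fold lower number from compound 1 to compound 2 (0.06 log units; within the scatter). Toward the limit, the steps are an at least 1.4-fold higher number from compound 1 to compound 3 (0.17 log units; that floor lies within the scatter) and an at least 1.6-fold higher number from compound 2 to compound 3 (0.22 log units; that floor lies within the scatter). Since none of these steps is shown beyond the scatter, only a small move to a lower number is expected in this assay. The expected step is an at least 1.8-fold lower number from compound 3 to compound 4 (0.25 log units; that floor lies within the scatter). Compound 4 is estimated at 55000 nM, with an expected range of 20000 nM to 100000 nM.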

Compound 4, half-maximal inhibitory concentration: 44500 nM
Compound 4: middle estimate off by 1.2-fold (0.09 log units), on the high side, and the stated range covers the measured number.
By their numbers in this assay, from the lowest: compounds 4, 2 and 1 (each within the scatter of the next). At a limit, above all of these: compound 3.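

Compound 3 reports only a limit in this assay: the limit of > 100000 nM in this assay, at which 1 of the 4 values shown sits.

With hydroxy(phenyl)methyl in place of 1-hydroxy-1-methylheptyl on a saturated chain carbon bound to a carbonyl carbon, the result is an at least 2.2-fold lower number from compound 3 to compound 4 (0.35 log units; beyond the scatter), the first step here shown beyond the scatter. The aromatic ring does not set compound 4 apart from its smaller relatives, since phenyl in place of propyl gives a 1.3-fold lower number from compound 2 to compound 4 (0.12 log units; within the scatter) and phenyl in place of hydrogen gives a 1.5-fold lower number from compound 1 to compound 4 (0.18 log units; within the scatter).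

Going by these compounds, whether an amine or a carboxylic acid at this place would move the number in this assay stays open. So does the effect of a substituted phenyl ring.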